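The compounds below may be only part of what the source reports. "The series", "measured", "known", "first", "only" and "open" are said of these compounds alone.

In an assay on isolated protein for inhibition of tyrosine-protein phosphatase non-receptor type 13 (Homo sapiens), read by spectrophotometry (a lower number here means a stronger inhibitor, a higher number a weaker inhibitor), compound 1 `O=C(COc1ccc2cc(C(O)(C(F)(F)F)C(F)(F)F)c(O)cc2c1)Nc1ccc(-c2ccccc2)cc1` gives 2800 nM. Compound 2 `Oc1ccc(-c2ccccc2)cc1C(O)(C(F)(F)F)C(F)(F)F` reaches only a limit of this assay, > 500000 nM. Compound 3 `COc1ccc(CNC(=O)COc2ccc3cc(C(O)(C(F)(F)F)C(F)(F)F)c(O)cc3c2)cc1OC` likewise returns only a limit, > 20000 nM. The single measured step, an at least 7.1-fold higher number from compound 1 to compound 3 (0.85 log units; beyond the scatter), ran toward weaker inhibition, so compound 3 stands at the weak end of the numbers shown and is known only as a limit (the limit of > 20000 nM in this assay, at which 1 of the 3 values shown sits). Compound 4 `CCN(CC)C(=O)COc1ccc2cc(C(O)(C(F)(F)F)C(F)(F)F)c(O)cc2c1` differs from compound 3 by diethylamino in place of (3,4-dimethoxybenzyl)amino on a carbonyl carbon. That measured step bears on this change, as it too altered the group on the amide-type nitrogen, and it rose beyond the scatter; compound 4 is expected to sit at or beyond the same limit. Compound 4 is therefore estimated at 40000 nM, within 10000 nM to 200000 nM, a step that the limit leaves unreadable from compound 3 to compound 4.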

Compound 4, half-maximal inhibitory concentration: > 20000 nM
Compound 4: no number, only a limit; the forecaster's own chance of this, stated with the estimate: 70%; the middle value is on the limit's open side.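

Going by these compounds alone, compound 4 gives only a limit of > 20000 nM in this assay and compound 3 is also known only as a limit, so no step between the two can be read. Going by these compounds, how diethylamino truly compares with (3,4-dimethoxybenzyl)amino stays open.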